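Two Substitutions, One Expected Outcome for Compound 4

This account rests on a few compounds, and the source may have more. Where it says the series, first, only, none or still open, it means among the compounds named here.

Of the compounds shown here, three have been tested in a functional assay on MCF7 cells (Homo sapiens) for antiproliferative activity, read by sulforhodamine B assay, with a stated time of 48 h; on this read-out lower numbers stand for stronger inhibition and higher numbers for weaker inhibition. Compound 1 `CCN1CCN(c2ccc(S(=O)(=O)Oc3ccccc3OC)cc2)C1=O` gives only a limit in this assay, > 100000 nM, and the value is a limit rather than a number. Compound 2 `CCN1CCN(c2ccc(S(=O)(=O)Oc3cccc(OC)c3)cc2)C1=O` differs from compound 1 by 3-methoxyphenyl in place of 2-methoxyphenyl on an oxygen. In this assay compound 2 gives 14000 nM, a step of an at least 7.1-fold lower number from compound 1 to compound 2 (0.85 log units; beyond the scatter). Compound 3 `CCCCN1CCN(c2ccc(S(=O)(=O)Oc3ccccc3OC)cc2)C1=O` differs from compound 1 by ethyl in place of hydrogen on a saturated chain carbon, two bonds along the chain from an amide-type nitrogen in a ring. In this assay compound 3 gives 3800 nM, a step of an at least 26-fold lower number from compound 1 to compound 3 (1.42 log units; beyond the scatter). Compound 3 has the lower number of the two measured compounds 2 and 3.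

Compound 4 `CCCCN1CCN(c2ccc(S(=O)(=O)Oc3cccc(OC)c3)cc2)C1=O` has not been measured. It differs from compound 3 by 3-methoxyphenyl in place of 2-methoxyphenyl on an oxygen, the same change, at the same place, that separates compound 2 from compound 1. Because that earlier step was an at least 7.1-fold lower number from compound 1 to compound 2 (0.85 log units; beyond the scatter), a step in the same direction is expected here, though its true size is uncertain because the limit of > 100000 nM in this assay, at which 1 of the 3 values shown sits, hides how far the first step really went. A somewhat smaller step, a 3.8-fold lower number from compound 3 to compound 4 (0.58 log units; beyond the scatter), is expected. Compound 4 is therefore estimated at 1000 nM, most likely between 300 nM and 3500 nM.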

Compound 4, half-maximal inhibitory concentration: 490 nM
Compound 4: the middle estimate sits 2.0-fold (0.31 log units) above what was measured; the measured number falls inside the stated range.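

In this assay the change from 2-methoxyphenyl to 3-methoxyphenyl gives a 7.8-fold lower number from compound 3 to compound 4 (0.89 log units; beyond the scatter), which is the same direction as on the core of compound 1: the same change on two cores in this assay, an at least 7.1-fold lower number (0.85 log units; beyond the scatter) from compound 1 to compound 2 and a 7.8-fold lower number (0.89 log units; beyond the scatter) from compound 3 to compound 4; the limit leaves it open whether they differ

The chain change, ethyl in place of hydrogen, also carries over, giving a 29-fold lower number from compound 2 to compound 4 (1.46 log units; beyond the scatter): the same change on two cores in this assay, an at least 26-fold lower number (1.42 log units; beyond the scatter) from compound 1 to compound 3 and a 29-fold lower number (1.46 log units; beyond the scatter) from compound 2 to compound 4; the limit leaves it open whether they differ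

Compound 1 gives > 100000 nM, a limit and not a number, so these compounds show a shared direction for each change on two cores, but they do not show a shared size, and they say nothing about any other core.

The compounds shown leave open how the number would move with a chain longer than the one in compound 4, or with an amine at the end of that chain. They also leave open whether 4-methoxyphenyl, or a phenyl ring carrying chloro instead of methoxy, would follow the same course as 3-methoxyphenyl.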